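The source may report more compounds than this note shows. Statements on the series, on what has been measured and on what is new or still open speak of the compounds shown alone.

Measured in a functional assay on THP-1 cells (Homo sapiens) for inhibition; a lower number here means a stronger inhibitor of growth, a higher number a weaker inhibitor of growth:
- Compound 1 `Cc1noc(C)c1-c1ccc2c(c1)c(CCc1ccccc1)cn2CCCCCCC(=O)NO`: 15500 nM
- Compound 2 `Cc1noc(C)c1-c1ccc2c(c1)c(CCc1ccc(F)cc1)cn2CCCCCCC(=O)NO`: 15500 nM
- Compound 3 `Cc1ccccc1Cc1cn(CCCCCC(=O)NO)c2ccc(-c3c(C)noc3C)cc12`: 15500 nM

Compound 3 stands level with compound 1 and compound 2, so these numbers do not separate the three. The move to compound 4 `Cc1ccccc1Cc1cn(CCCCCCC(=O)NO)c2ccc(-c3c(C)noc3C)cc12` changes the end of the chain, from 3-(hydroxycarbamoyl)propyl to 4-(hydroxycarbamoyl)butyl: (hydroxycarbamoyl)methyl in place of hydroxycarbamoyl on a saturated chain carbon, five bonds along the chain from an aromatic nitrogen. Going by the values given here, no measured step covers this change. The only one available, no change at the digits printed from compound 1 to compound 2 (within the scatter), is a different change, fluoro in place of hydrogen on an aromatic carbon, and gives only weak guidance. With no evidence for a direction, no shift beyond the scatter is expected in this assay, and the expected step is no change at the digits printed from compound 3 to compound 4 (within the scatter). For compound 4 the estimate is 15500 nM, with an expected range of 6000 nM to 20000 nM.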

Compound 4, concentration for 50% growth inhibition: 15500 nM
Compound 4: middle estimate and measured number agree at the digits printed; measured number inside the range.
By their numbers in this assay, from the lowest: compounds 1, 2, 3 and 4 (each within the scatter of the next).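

In this assay the chain end tolerates (hydroxycarbamoyl)methyl in place of hydroxycarbamoyl, with no change at the digits printed from compound 3 to compound 4 (within the scatter) on this change. At the saturated chain carbon bound to an aromatic carbon, 2-methylphenyl in place of 4-fluorobenzyl gives no change at the digits printed from compound 2 to compound 4 (within the scatter) as its step, and 2-methylphenyl in place of benzyl gives no change at the digits printed from compound 1 to compound 4 (within the scatter) as its step, so neither site separates these compounds. Nothing measured here offers an explanation for this flat picture.

Still open, from the compounds shown here alone, is whether a longer chain, or a carboxylic acid in place of the hydroxycarbamoyl end, would give a different number in this assay as a read-out.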